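Chloro for hydrogen on the core of compound 1

The source may report more compounds than this note shows. Statements on the series, on what has been measured and on what is new or still open speak of the compounds shown alone.

Compound 1 `ClCc1ccc(Cn2cnc3c(Cl)ncnc32)cc1` is measured in a functional assay on OVCAR-8 cells (Homo sapiens) for cytotoxicity, read by sulforhodamine B assay, with a stated time of 48 h (on this read-out lower numbers stand for higher toxicity in this test and higher numbers for lower toxicity in this test), and gives 64600 nM. Among the three numbers to hand, compound 1 stands second highest. Its nearest neighbour is compound 3 `ClCc1ccccc1Cn1cnc2nc(Cl)nc(Cl)c21`, which gives 75900 nM, a gap within the scatter. Furthest from it is compound 2 `ClCc1cccc(Cn2cnc3nc(Cl)nc(Cl)c32)c1`, which gives 45700 nM, also within the scatter. No two of these compounds differ in only one place, so no single measured step is available.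

Compound 4 `ClCc1ccc(Cn2cnc3c(Cl)nc(Cl)nc32)cc1` is not yet measured. It differs from compound 1 by chloro in place of hydrogen on an aromatic carbon, the new chloro sitting on an aromatic carbon of a six-membered aromatic ring with two nitrogen, between two ring nitrogen atoms. Compounds 2 and 3 carry two chloro groups on the same core and their values sit within the scatter of compound 1, so no step beyond the scatter is expected here. The step from compound 1 to compound 4 is estimated at a 1.2-fold lower number from compound 1 to compound 4 (0.07 log units; within the scatter). For compound 4 the expected value is 55000 nM, with a range from 25000 nM to 120000 nM.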

Compound 4, concentration lethal to 50% of the cells: 72400 nM
Estimate against measurement, compound 4: 1.3-fold (0.12 log units) below; low and high end bracket the measured number.
By their numbers in this assay, from the lowest: compounds 2, 1, 4 and 3 (each within the scatter of the next).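

Among the compounds shown here, this is the first step that changes one place only. In this assay chloro in place of hydrogen on an aromatic carbon gives a 1.1-fold higher number from compound 1 to compound 4 (0.05 log units; within the scatter) and so leaves the read-out within the scatter at this position, between two ring nitrogen atoms. The series offers no independent measurement that would explain this result.

For the compounds shown here, whether an amine, a methoxy group or a longer chain at this same position would also stay within the scatter remains open, as the single step covers only hydrogen and chloro. Also open, going by these compounds, is whether the same exchange would read alike with the arrangement of compound 2 or compound 3.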